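Two aminothiophenes and a methoxyphenyl replacement

A few compounds are considered here, and "the series" means these few. Any claim that something is new, unique, unknown or untested is made for them only; others in the source may bear on it.

Compound 1 `COc1ccc(-c2sc(N)c(C(=O)c3ccc(Cl)cc3)c2C)cc1` and compound 2 `CC(C)(C)Cc1c(-c2ccc(F)cc2)sc(N)c1C(=O)c1ccc(Cl)cc1` were both tested in an assay on CHO cells for displacement of a labelled ligand from adenosine receptor A1 (Homo sapiens), read by scintillation counting, tested at 10 uM; a lower number here means less inhibition, a higher number more inhibition at the concentration tested (going by the name of the read-out). In this assay compound 1 gives 1%, and in this assay compound 2 gives 1%, so compound 2 stands level with compound 1 at the digits shown, the two values lying within the scatter of each other. Neither compound shows appreciable inhibition at the concentration tested.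

Compound 3 `COc1ccccc1-c1sc(N)c(C(=O)c2ccc(Cl)cc2)c1CC(C)(C)C` has not yet been measured. It differs from compound 2 by 2-methoxyphenyl in place of 4-fluorophenyl on an aromatic carbon. Among the compounds with values here, no step between two measured compounds is known for such a change, and the only numbers available show both measured compounds at a very low read-out. The step from compound 2 to compound 3 in this assay is therefore expected to be small, probably not beyond the scatter, as a number 2 percentage points higher from compound 2 to compound 3 (within the scatter). For compound 3 the estimate in this assay is 3%, within the range from -8% to 15%.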

Compound 3, a percentage reported as inhibition, at one concentration (the size of the read-out at that concentration, not a potency): 1%
Compound 3: middle estimate off by 2 percentage points, on the high side, within the range that was stated.
By their numbers in this assay, from the lowest: compounds 1, 2 and 3 (each within the scatter of the next).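

Within the data shown here, the exchange of 4-fluorophenyl for 2-methoxyphenyl, on the aromatic carbon next to the ring sulfur, gives the first step that can be read at this position: in this assay there is no change at the digits printed from compound 2 to compound 3 (within the scatter). The entering group brings an oxygen and a hydrogen-bond acceptor that the 4-fluorophenyl group does not have, and with them the read-out shows no appreciable inhibition at the concentration tested. Nothing at hand explains this result.

With all three compounds reading so low, the step cannot show whether these two groups would differ on a compound with appreciable inhibition. As far as these compounds go, it also remains open whether an amine or a carboxylic acid at this position, or a longer chain in place of the neopentyl group, would move the read-out.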